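Removing One Chloro Group From an Inactive Dichlorophenyl Analogue

A few compounds are considered here, and "the series" means these few. Any claim that something is new, unique, unknown or untested is made for them only; others in the source may bear on it.

Measured compounds:
- Compound 1 `Cc1nc(-c2ccc(Cl)cc2)sc1C(=O)CSc1nc(-c2ccc(Cl)c(Cl)c2)c(C#N)c(=O)[nH]1`: 101%
- Compound 2 `COc1ccc(-c2nc(C)c(C(=O)CSc3nc(N)c(C#N)c(-c4ccc(OC)cc4)n3)s2)cc1`: 35.6%
- Compound 3 `Cc1nc(-c2ccccc2)sc1C(=O)CSc1nc(-c2ccc(Cl)c(Cl)c2)c(C#N)c(=O)[nH]1`: 98.6%

All three were tested in a functional assay on U-87MG ATCC cells for antiproliferative activity against U-87 MG (Homo sapiens), read by MTT assay, with a stated time of 48 h, tested at 5 uM; a higher number here means a weaker effect of the compound at the concentration tested, a lower number a stronger effect. Compound 1 gives 101%, the highest of the three numbers, meaning it shows no measurable effect at the concentration used. Compound 3 lies within the scatter of compound 1, with a number 2.4 percentage points lower from compound 1 to compound 3 (within the scatter). Compound 2 is the only one clearly apart, and it differs from compound 1 in several places at once, so its lower number cannot be traced to any single change.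

Compound 4 `Cc1nc(-c2ccc(Cl)cc2)sc1C(=O)CSc1nc(-c2cccc(Cl)c2)c(C#N)c(=O)[nH]1` has not yet been measured. It differs from compound 1 by hydrogen in place of chloro on an aromatic carbon, so that the 3,4-dichlorophenyl becomes a 3-chlorophenyl. For the measured compounds named here, the only measured step of the same kind, a chloro to hydrogen swap on the other aromatic ring, is the one from compound 1 to compound 3, and it stayed within the scatter. On that basis no step beyond the scatter is expected in this assay, in either direction.

Compound 4 is therefore estimated at 97%, with a range from 82% to 108%, which means an expected step of a number 4 percentage points lower from compound 1 to compound 4 (within the scatter).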

Compound 4, a percentage reported as activity, at one concentration (the size of the read-out at that concentration, not a potency): 80.2%
Compound 4: the middle estimate sits 16.8 percentage points above what was measured; the whole stated range lies above it.
By their numbers in this assay, from the lowest: compound 2; then compound 4; then compounds 3 and 1 (each within the scatter of the next).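

Removing the chloro group from the 3,4-dichlorophenyl to leave a 3-chlorophenyl gives a number 20.8 percentage points lower from compound 1 to compound 4 (beyond the scatter) in this assay and shows that this position, para to a large group and ortho to a chloro group, is sensitive to the change. The same kind of swap on the other aromatic ring gave a number 2.4 percentage points lower from compound 1 to compound 3 (within the scatter) in the same test, so among these compounds the outcome of replacing chloro with hydrogen depends on which ring carries it. Nothing available explains why losing this particular chloro group lowers the number.

The compounds shown leave open whether the remaining chloro group of compound 4 contributes to this effect, since no analogue here lacks it or keeps only the other chloro group of the 3,4-dichlorophenyl. They also leave open whether hydrogen is the best replacement at this position, as a fluoro group or an amine there would test whether the effect depends on simply removing the chloro group or on what takes its place.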